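This account rests on a few compounds, and the source may have more. Where it says the series, first, only, none or still open, it means among the compounds named here.

In a functional assay on SMMC-7721 cells (Homo sapiens) for cytotoxicity, read by MTT assay, with a stated time of 72 h (on this read-out higher numbers stand for weaker inhibition and lower numbers for stronger inhibition), compound 3 `COc1cc2c(Oc3ccc(NC(=O)c4cc(-c5ccc(F)cc5)nc5ccccc45)cc3F)ccnc2cc1OCCCN1CCCCC1` gives 74 nM, the lowest of the three numbers recorded so far: compound 1 `COc1cc2c(Oc3ccc(NC(=O)c4cc(-c5ccccc5)nc5ccccc45)cc3F)ccnc2cc1OCCCN1CCCCC1` gives 290 nM and compound 2 `COc1cccc(-c2cc(C(=O)Nc3ccc(Oc4ccnc5cc(OCCCN6CCCCC6)c(OC)cc45)c(F)c3)c3ccccc3n2)c1` gives 380 nM. Compound 4 `COc1cc2c(Oc3ccc(NC(=O)c4cc(-c5ccc(Cl)c(Cl)c5)nc5ccccc45)cc3F)ccnc2cc1OCCCN1CCCCC1` differs from compound 3 by 3,4-dichlorophenyl in place of 4-fluorophenyl on an aromatic carbon. Going by the values given here, two measured steps touch the same place on the shared core: a 3.9-fold lower number from compound 1 to compound 3 (0.59 log units; beyond the scatter), and a 5.1-fold lower number from compound 2 to compound 3 (0.71 log units; beyond the scatter). Neither involves a 3,4-dichlorophenyl, so the data give no direct guide to the size of this change. For compound 4 an estimated step of a 1.4-fold higher number from compound 3 to compound 4 (0.13 log units; within the scatter) is expected, within or only slightly beyond the scatter. The estimate for compound 4 in this assay is 100 nM, with a range from 35 nM to 300 nM.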

Compound 4, half-maximal inhibitory concentration: 770 nM
Compound 4: middle estimate off by 7.7-fold (0.89 log units), on the low side; the measured number lies above the stated range.
By their numbers in this assay, from the lowest: compound 3; then compounds 1 and 2 (each within the scatter of the next); then compound 4.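

In this assay this position, next to the ring nitrogen, proves far less forgiving than the earlier swaps suggested: 3,4-dichlorophenyl in place of 4-fluorophenyl gives a 10-fold higher number from compound 3 to compound 4 (1.02 log units; beyond the scatter), the largest step seen here. Halogen on this ring therefore does not in itself lower the number, since the same group also reads worse than phenyl, with a 2.7-fold higher number from compound 1 to compound 4 (0.42 log units; beyond the scatter), and than 3-methoxyphenyl, with a 2.0-fold higher number from compound 2 to compound 4 (0.31 log units; beyond the scatter). Nothing measured here explains the difference. On these data alone, whether a single chlorine, as in 4-chlorophenyl or 3-chlorophenyl, already raises the number remains open, as does the reading of 3,4-difluorophenyl. How an amine or a carboxylic acid on this ring would read is also unknown.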